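This account rests on a few compounds, and the source may have more. Where it says the series, first, only, none or still open, it means among the compounds named here.

Working notes on a selenocyanate and diselenide set tested in a functional assay on PC-3 cells (Homo sapiens) for cytotoxicity, read by MTT assay, with a stated time of 72 h; a lower number here means a stronger inhibitor of growth, a higher number a weaker inhibitor of growth. Compound 1 `CCCOC(=O)Nc1ccc([Se]C#N)cc1` gives the highest number of the three measured, at 21100 nM. Within the data shown here, the diselenide compound 2 `O=C(Nc1ccc([Se][Se]c2ccc(NC(=O)Oc3ccc(F)cc3)cc2)cc1)Oc1ccc(F)cc1` gives 4900 nM, and the diselenide compound 3 `O=C(Nc1ccc([Se][Se]c2ccc(NC(=O)OCc3ccc([N+](=O)[O-])cc3)cc2)cc1)OCc1ccc([N+](=O)[O-])cc1` gives 6400 nM; both numbers sit below that of compound 1, beyond the scatter, with no single-point step connecting them to it. Compound 4 `N#C[Se]c1ccc(NC(=O)Oc2ccccc2)cc1` is not yet measured. It differs from compound 1 as follows: phenyl in place of propyl on an oxygen next to a carbonyl group. Among the measured compounds shown here, no measured pair shows this change on its own. A modest move toward a lower number is expected, a 1.8-fold lower number from compound 1 to compound 4 (0.25 log units; within the scatter), at the edge of the scatter rather than clearly beyond it. For compound 4 the estimated value is 12000 nM, in the range 4000 nM to 35000 nM.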

Compound 4, concentration for 50% growth inhibition: 9100 nM
For compound 4 the middle estimate is 1.3-fold (0.12 log units) above the measured one, within the range that was stated.
By their numbers in this assay, from the lowest: compounds 2, 3 and 4 (each within the scatter of the next); then compound 1.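

Phenyl in place of propyl on an oxygen next to a carbonyl group gives a 2.3-fold lower number from compound 1 to compound 4 (0.37 log units; beyond the scatter) in this assay and is the only single-point step in the series so far. It shows that this position affects the read-out while the selenocyanate stays unchanged, with a modest step that lies beyond the scatter. Nothing available explains the step. Still open, on these data alone, is how a longer chain, such as butyl, or a ring-bearing amine would read on this oxygen. Compounds 2 and 3 remain unconnected to this step, so its relevance to the diselenides is also unknown.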